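This account rests on a few compounds, and the source may have more. Where it says the series, first, only, none or still open, it means among the compounds named here.

Compound 1 `C#CC[C@@]1(O)[C@@H](CO)O[C@@H](n2ccc(=O)[nH]c2=O)[C@@H]1O` and compound 2 `C#C[C@@H]1[C@@H](O)[C@H](n2ccc(N)nc2=O)O[C@@H]1CO` share a nucleoside core and were both tested in a functional assay on L1210 cells (Mus musculus), read by MTT assay; on this read-out lower numbers stand for stronger inhibition and higher numbers for weaker inhibition. In this assay compound 1 gives > 350000 nM, which is a limit of the assay and not a number. In this assay compound 2 likewise gives > 350000 nM, again a limit rather than a number. Thus compound 1 stands at the same limit as the only other value shown, and no ordering between the two can be drawn. Compound 3 `CCC#C[C@@]1(O)[C@@H](CO)O[C@@H](n2ccc(=O)[nH]c2=O)[C@@H]1O` differs from compound 1 by but-1-yn-1-yl in place of propargyl on a saturated ring carbon. Going by the values given here, because both values shown sit at the limit of > 350000 nM in this assay, at which 2 of the 2 values shown sit, no step between measured compounds can be sized. The step from compound 1 to compound 3 is therefore expected to be a number no higher from compound 1 to compound 3 (the limit leaves the size open), none beyond the scatter. Compound 3 is expected to give 350000 nM in this assay, with a range from 100000 nM to 1000000 nM.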

Compound 3, half-maximal inhibitory concentration: 338000 nM
Estimate against measurement, compound 3: 1.0-fold (0.02 log units) above; measured number inside the range.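

In this assay compound 3 gives 338000 nM, the first actual number among the compounds shown for a group on this saturated ring carbon. The values of compound 1 and compound 2 are limits and not numbers. With but-1-yn-1-yl in place of propargyl, the reading is an at least 1.0-fold lower number from compound 1 to compound 3 (0.01 log units; that floor lies within the scatter). The true size of this step stays open because compound 1 stands at a limit: the limit of > 350000 nM in this assay, at which 2 of the 3 values shown sit.

The compounds shown leave open whether a chain longer than but-1-yn-1-yl on this carbon would move the number in this assay beyond the scatter. They also leave open what an amine or a carboxylic acid at the end of such a chain would do to the value of compound 3.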